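A few compounds are considered here, and "the series" means these few. Any claim that something is new, unique, unknown or untested is made for them only; others in the source may bear on it.

Measured so far:
Compound 1, `COc1cc(-c2nn(-c3cccc(NC(=O)Nc4ccc(Cl)c(Cl)c4)c3)cc2-c2ccncc2)ccc1Cl`: > 50000 nM
Compound 2, `COc1cc(-c2nn(-c3cccc(NC(=O)Nc4cccc(C(F)(F)F)c4)c3)cc2-c2ccncc2)ccc1Cl`: > 50000 nM

In a functional assay on UO-31 cells (Homo sapiens) for inhibition, read by sulforhodamine B assay, with a stated time of 48 h (a higher number here means that more compound is tolerated, a lower number that less compound is tolerated), compound 1 reaches only a limit of the assay, > 50000 nM. Compound 2 likewise shows only a limit in this assay, > 50000 nM. Because both readings stop at the limit of > 50000 nM in this assay, at which 2 of the 2 values shown sit, the step from one to the other, a step that the two limits leave unreadable from compound 1 to compound 2, cannot be sized: the swap of a 3-(trifluoromethyl)phenyl for a 3,4-dichlorophenyl on the urea nitrogen left the outcome unchanged in kind, with no number to compare.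

Compound 3, `COc1cc(-c2nn(-c3cccc(NC(=O)Nc4ccc(Cl)c(C(F)(F)F)c4)c3)cc2-c2ccncc2)ccc1Cl`, differs from compound 2 by chloro in place of hydrogen on an aromatic carbon, a chloro in place of hydrogen on an aromatic carbon. Within the data shown here, the only measured step that touches this part of the molecule is the one from compound 1 to compound 2, and it is unreadable, so no direction and no size can be drawn from it. With both neighbours sitting at the limit, the expectation for compound 3 is a reading of the same kind, an estimated step that the limit leaves unreadable from compound 2 to compound 3. Compound 3 is therefore expected to give about 60000 nM in this assay, in a range from 25000 nM to 150000 nM.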

Compound 3, concentration lethal to 50% of the cells: > 32500 nM
Compound 3 ended at the assay's limit; the forecaster's own chance of this, stated with the estimate: 75%; the middle value does not contradict the limit.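

In this assay compound 3 gives > 32500 nM, which is a limit of the assay and not a number. Its steps from compound 2 and from compound 1 cannot be read. The compounds shown leave open whether swapping chloro, hydrogen or trifluoromethyl on this aromatic ring changes the reading at all, as compounds 1, 2 and 3 all stop at limits.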